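Chlorine for Methoxy on an Unchanged Core

This account rests on a few compounds, and the source may have more. Where it says the series, first, only, none or still open, it means among the compounds named here.

Of the compounds shown here, three that share one core have been tested in a toxicity assay on HEK-293T cells (Homo sapiens) for inhibition, read by MTT assay, with a stated time of 24 h (on this read-out lower numbers stand for higher toxicity in this test and higher numbers for lower toxicity in this test), and in each case the assay reached only its limit. Compound 1 `O=c1oc2ccccc2c(N2CCN(c3cccc(C(F)(F)F)c3)CC2)c1CO` gives > 50000 nM in this assay, which is a limit and not a number. Compound 2 `O=c1oc2ccccc2c(N2CCN(c3ccccc3F)CC2)c1CO` gives > 50000 nM in this assay, again a limit. Compound 3 `COc1ccccc1N1CCN(c2c(CO)c(=O)oc3ccccc23)CC1` gives > 50000 nM in this assay, also a limit. Among the compounds with values here, the one change between measured compounds, methoxy in place of fluoro on an aromatic carbon, is a step that the two limits leave unreadable from compound 2 to compound 3, so its size cannot be read. Compound 3 thus stands at the limit together with the other two values shown, as the evidence records: the limit of > 50000 nM in this assay, at which 3 of the 3 values shown sit. Compound 4 `O=c1oc2ccccc2c(N2CCN(c3cccc(Cl)c3)CC2)c1CO` differs from compound 3 as follows: 3-chlorophenyl in place of 2-methoxyphenyl on an amine nitrogen in a ring. Within the data shown here, no measured step bears on this change with a readable size, and all three values shown sit at the limit, so no step beyond the scatter is expected in this assay in either direction. Compound 4 is therefore expected to give about 80000 nM, within 35000 nM to 250000 nM, which means an expected step that the limit leaves unreadable from compound 3 to compound 4, most likely again reported only as a limit.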

Compound 4, half-maximal cytotoxic concentration: > 50000 nM
Compound 4: a limit, no number (the forecaster's own chance of this, stated with the estimate: 85%); the middle value is on the limit's open side.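

Within the data shown here, compound 4, like compound 1, compound 2 and compound 3, gives only a limit in this assay, so no step among them can be read: the limit of > 50000 nM in this assay, at which 4 of the 4 values shown sit. The compounds shown leave open which change to the shared core, if any, would give a measurable number in this assay.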